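The compounds below may be only part of what the source reports. "The series", "measured", "known", "first", "only" and "open" are said of these compounds alone.

Measured in a physicochemical assay for acid dissociation:
Compound 1 `CCC(CC)c1ccc2c(NCCCNCc3cc(F)ccc3OC)ccnc2c1` gives 9.47.
Compound 2 `CCC(CC)c1ccc2c(NCCCNCc3ccco3)ccnc2c1` gives 9.47.
Compound 3 `COc1ccc(-c2ccc3c(NCCCNCc4ccco4)ccnc3c2)cc1` gives 9.47.

Compound 1 stands level with compounds 2 and 3: the step of no change at the digits printed from compound 1 to compound 2 (within the scatter) and the step of no change at the digits printed from compound 2 to compound 3 (within the scatter) both stay within the scatter, so the three values are indistinguishable here.

Compound 4 `COc1ccc(F)cc1CNCCCNc1ccnc2cc(CC3CCCCC3)ccc12` is still to be measured in this assay. It differs from compound 1 as follows: cyclohexylmethyl in place of pentan-3-yl on an aromatic carbon. The step that bears on this is no change at the digits printed from compound 2 to compound 3 (within the scatter), where the group on the same aromatic carbon of the shared core was exchanged and the value was flat; no change at the digits printed from compound 1 to compound 2 (within the scatter) was flat as well. No step beyond the scatter is therefore expected in this assay for compound 4, the expected step being no change at the digits printed from compound 1 to compound 4 (within the scatter). Compound 4 is estimated at 9.47, with a range of 9.2 to 9.8.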

Compound 4, acid dissociation constant: 9.47
For compound 4 middle estimate and measured number coincide at the digits printed; measured number inside the range.
By their numbers in this assay, from the lowest: compounds 1, 2, 3 and 4 (each within the scatter of the next).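

In this assay, cyclohexylmethyl in place of pentan-3-yl on the aromatic carbon gives no change at the digits printed from compound 1 to compound 4 (within the scatter). This extends the flat reading at this position to a group with a six-membered non-aromatic ring, and to compounds carrying 5-fluoro-2-methoxyphenyl rather than furan-2-yl on the chain. No measurement available explains this flat reading.

Going by these compounds, whether an amine or a carboxylic acid on this aromatic carbon would move the value remains open. So does the effect of a longer chain in the shared core.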